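A few compounds are considered here, and "the series" means these few. Any claim that something is new, unique, unknown or untested is made for them only; others in the source may bear on it.

Three compounds share one core and differ only in the aryl group on an amine nitrogen in a ring. Compound 1 `COc1ccccc1N1CCN(Cn2nc(-c3ccc4c(c3)OCCO4)oc2=S)CC1` carries a 2-methoxyphenyl, and in a functional assay on HepG2 cells (Homo sapiens) for antiproliferative activity, read by MTT assay, with a stated time of 48 h (on this read-out lower numbers stand for stronger inhibition and higher numbers for weaker inhibition), compound 1 gives 15500 nM. Compound 3 `O=[N+]([O-])c1ccc(N2CCN(Cn3nc(-c4ccc5c(c4)OCCO5)oc3=S)CC2)cc1` carries a 4-nitrophenyl, and in this assay compound 3 gives 29500 nM; with a 1.9-fold higher number from compound 1 to compound 3 (0.28 log units; within the scatter), these two cannot be told apart. Compound 2 `Fc1ccc(N2CCN(Cn3nc(-c4ccc5c(c4)OCCO5)oc3=S)CC2)cc1` carries a 4-fluorophenyl, and in this assay compound 2 reaches only the limit > 50000 nM. Compound 4 `S=c1oc(-c2ccc3c(c2)OCCO3)nn1CN1CCN(c2ccccc2Cl)CC1` is not yet measured; it differs from compound 3 by 2-chlorophenyl in place of 4-nitrophenyl on an amine nitrogen in a ring. The relevant steps are a 1.9-fold higher number from compound 1 to compound 3 (0.28 log units; within the scatter) and an at least 3.2-fold higher number from compound 1 to compound 2 (0.50 log units; beyond the scatter). A 2-chlorophenyl resembles the 2-methoxyphenyl of compound 1 more than the 4-fluorophenyl of compound 2, so the expected step of a 1.6-fold lower number from compound 3 to compound 4 (0.21 log units; within the scatter) is small and within the scatter. Compound 4 is therefore estimated at 18000 nM, between 8000 nM and 45000 nM.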

Compound 4, half-maximal inhibitory concentration: 11400 nM
Compound 4: the middle estimate sits 1.6-fold (0.20 log units) above what was measured, and the stated range covers the measured number.
By their numbers in this assay, from the lowest: compounds 4, 1 and 3 (each within the scatter of the next, the first and the last beyond it). At a limit, above all of these: compound 2.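

Putting chloro in place of methoxy on the aromatic ring changes nothing that can be told apart, with a 1.4-fold lower number from compound 1 to compound 4 (0.13 log units; within the scatter). The 2-chlorophenyl does separate itself from the 4-nitrophenyl, which the 2-methoxyphenyl did not, with a 2.6-fold lower number from compound 3 to compound 4 (0.41 log units; beyond the scatter), and from the 4-fluorophenyl, with an at least 4.3-fold lower number from compound 2 to compound 4 (0.64 log units; beyond the scatter). Compound 2 stands at a limit, so that last step is only a floor: the limit of > 50000 nM in this assay, at which 1 of the 4 values shown sits. On these data alone, whether an unsubstituted phenyl or a benzyl group on the same nitrogen would keep this level stays open.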